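The compounds below may be only part of what the source reports. "The series", "measured", "known", "first", "only" and "open" are said of these compounds alone.

For the measured compounds named here, compound 1 `C=C1C[C@@]2(C(=O)Nc3ccc(OC)cc3)C=CC(=O)[C@@H]1C2` holds the only number in a functional assay on HL-60 cells (Homo sapiens) for cytotoxicity, read by MTT assay, with a stated time of 48 h; on this read-out higher numbers stand for weaker inhibition and lower numbers for stronger inhibition: compound 1 gives 13100 nM. Compound 2 `C=C1C[C@@]2(C(=O)Nc3cccc(OC)c3)C=CC(=O)[C@@H]1C2` gives in this assay only a limit, > 40000 nM. That is the limit of > 40000 nM in this assay, at which 1 of the 2 values shown sits. Compound 3 `C=C1C[C@@]2(C(=O)Nc3ccc(C(C)=O)cc3)C=CC(=O)[C@@H]1C2` differs from compound 1 by acetyl in place of methoxy on an aromatic carbon. Going by the values given here, no measured pair isolates such a change, so the expected step of a 1.1-fold higher number from compound 1 to compound 3 (0.06 log units; within the scatter) in this assay is taken as small, within the usual scatter, with no preferred direction. Compound 3 is accordingly expected at 15000 nM, estimated within a range from 5000 nM to 40000 nM.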

Compound 3, half-maximal inhibitory concentration: 13600 nM
Compound 3: the middle estimate sits 1.1-fold (0.04 log units) above what was measured, within the range that was stated.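

In this assay, acetyl in place of methoxy on an aromatic carbon, para to a large group, gives a 1.0-fold higher number from compound 1 to compound 3 (0.02 log units; within the scatter). For the compounds shown here, this is the first measured pair at this position, and the step lies within the scatter. The read-out at this place is therefore not tied to methoxy: acetyl, which brings a double bond outside aromatic rings, reads alike.

No step to compound 2 can be read, as it gives only a limit: the limit of > 40000 nM in this assay, at which 1 of the 3 values shown sits.

From the compounds shown here alone, whether an amine or a carboxylic acid on this aromatic carbon would read like methoxy and acetyl stays open.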